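A hydroxy group added to compound 2

The source may report more compounds than this note shows. Statements on the series, on what has been measured and on what is new or still open speak of the compounds shown alone.

Three compounds measured so far in a functional assay on SF-295 cells (Homo sapiens) for cytotoxicity; on this read-out lower numbers stand for stronger inhibition of growth and higher numbers for weaker inhibition of growth
Compound 1 `OCC#Cc1ccccc1C#Cc1ccccc1` gives 20600 nM
Compound 2 `OCCCCC#Cc1ccccc1C#Cc1ccccc1` gives 150 nM
Compound 3 `OCCCCC#Cc1ccccc1C#Cc1cccc(C(F)(F)F)c1` gives 16500 nM

Compound 2 at 150 nM has the lowest number of the three, and compound 4 `OCCCCC#Cc1ccccc1C#Cc1ccc(O)cc1` departs from it by one change. The change hydroxy in place of hydrogen on an aromatic carbon is hydroxy in place of hydrogen on an aromatic carbon. For the measured compounds named here, the nearest precedent is trifluoromethyl in place of hydrogen on an aromatic carbon, the large step of a 110-fold higher number from compound 2 to compound 3 (2.04 log units; beyond the scatter) in the measured series. The chain step a 140-fold lower number from compound 1 to compound 2 (2.14 log units; beyond the scatter) lies elsewhere in the molecule and bears less on this change. A single precedent with a different group fixes no size, so a smaller rise in this assay is expected. The expected step is a 10-fold higher number from compound 2 to compound 4 (1.00 log units; beyond the scatter) in the same direction. Compound 4 is estimated at 1500 nM with 200 nM to 12000 nM as the expected range.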

Compound 4, concentration for 50% growth inhibition: 16200 nM
Estimate against measurement, compound 4: 11-fold (1.03 log units) below; the measured number lies above the stated range.
By their numbers in this assay, from the lowest: compound 2; then compounds 4, 3 and 1 (each within the scatter of the next).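

In this assay hydroxy in place of hydrogen on an aromatic carbon, para to a large group, gives a 110-fold higher number from compound 2 to compound 4 (2.03 log units; beyond the scatter) and so costs compound 2 nearly all of its growth inhibition. With a 110-fold higher number from compound 2 to compound 3 (2.04 log units; beyond the scatter) as the other printed case, two quite different groups on the outer ring have now each raised the number beyond the scatter, and the unsubstituted phenyl of compound 2 remains the only ring with a low number. Whether an amine, a fluorine or a methoxy group at this ring would fare any better stays open, and no measurement shown here accounts for the rise.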